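The source may report more compounds than this note shows. Statements on the series, on what has been measured and on what is new or still open speak of the compounds shown alone.

Compound 2 `COC(=O)C1=C(C)N=C(C)/C(=C(\O)OC)C1c1cccc(Cl)c1Cl` is tested in a functional assay (muscle tissue) with Cavia porcellus as the target (a higher number here means that more compound is needed for the effect, a lower number that less compound is needed), where compound 2 gives 19.1 nM. Among three measured compounds it holds the second highest number. Compound 1 `COC(=O)C1=C(C)N=C(C)/C(=C(/O)OC)C1c1c(F)cccc1Cl` is its nearest neighbour; in this assay compound 1 gives 7.59 nM, a lower number that lies beyond the scatter. Compound 3 `COC(=O)C1=C(C)N=C(C)/C(=C(\O)OC)C1c1cc(OC)c(OC)cc1OC` is the furthest and gives 1000000 nM in this assay, far beyond the scatter in the other direction. Compound 4 `COC(=O)C1=C(C)N=C(C)/C(=C(\O)OC)C1c1cccc(Br)c1` differs from compound 2 in one place: 3-bromophenyl in place of 2,3-dichlorophenyl on a saturated ring carbon. Among the measured compounds shown here, no measured pair shows this exact change. Compound 4 is expected to need somewhat more compound than compound 2, with a step of a 2.1-fold higher number from compound 2 to compound 4 (0.32 log units; beyond the scatter) of modest size, though possibly within the scatter. Compound 4 is estimated at 40 nM in this assay, within a range from 10 nM to 200 nM.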

Compound 4, half-maximal effective concentration: 1.29 nM
For compound 4 the middle estimate is 31-fold (1.49 log units) above the measured one; the whole stated range lies above it.
By their numbers in this assay, from the lowest: compound 4; then compound 1; then compound 2; then compound 3.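

In this assay, 3-bromophenyl in place of 2,3-dichlorophenyl on the saturated ring carbon gives a 15-fold lower number from compound 2 to compound 4 (1.17 log units; beyond the scatter), a large step. This position therefore does not require the 2,3-dichlorophenyl group, and a phenyl ring carrying bromine alone needs less compound for the effect. No evidence at hand explains this step.

The change removes both chlorines and adds bromine at once, leaving the contribution of each part open. From the compounds shown here alone, how 3-chlorophenyl, 2-bromophenyl or a phenyl ring bearing an amine or a carboxylic acid would behave on this carbon also remains open.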